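A few compounds are considered here, and "the series" means these few. Any claim that something is new, unique, unknown or untested is made for them only; others in the source may bear on it.

In a functional assay on SW480 cells (Homo sapiens) for antiproliferative activity, read by MTT assay, with a stated time of 48 h (on this read-out lower numbers stand for stronger inhibition and higher numbers for weaker inhibition), the compounds share one core and differ in their saturated chain. Compound 1 `CCCCCCC(CCO)n1cnc2c(NC)ncnc21` reads > 50000 nM, which is a limit of the assay and not a number. Compound 2 `CCCCCCCCCC(CCO)n1cnc2c(NC)ncnc21` gives 4450 nM, and compound 3 `CCCCCCCCCCC(CCO)n1cnc2c(NC)ncnc21` gives 12000 nM, the higher of the two actual numbers. Compound 4 `CCCCCCCCCCCC(CCO)n1cnc2c(NC)ncnc21` differs from compound 3 by methyl in place of hydrogen on a saturated chain carbon, ten or more bonds along the chain from an aromatic nitrogen, with methyl in place of hydrogen on a saturated chain carbon, ten or more bonds along the chain from an aromatic nitrogen. For the measured compounds named here, the closest precedent is the same change, a 2.7-fold higher number from compound 2 to compound 3 (0.43 log units; beyond the scatter), a modest step toward weaker inhibition. The steps of an at least 11-fold lower number from compound 1 to compound 2 (1.05 log units; beyond the scatter) and an at least 4.1-fold lower number from compound 1 to compound 3 (0.61 log units; beyond the scatter) lie at another place on the chain and bear on it less directly, and they run the opposite way. A second modest rise in the number is therefore expected in this assay, resting on that single precedent. Compound 4 is expected at 26000 nM, with an estimated range of 11000 nM to 50000 nM. The estimated change is a 2.2-fold higher number from compound 3 to compound 4 (0.34 log units; beyond the scatter).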

Compound 4, half-maximal inhibitory concentration: 12800 nM
Beside the measured number, compound 4's estimate is 2.0-fold (0.31 log units) above it; the measured number falls inside the stated range.
By their numbers in this assay, from the lowest: compound 2; then compounds 3 and 4 (each within the scatter of the next). At a limit, above all of these: compound 1.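

In this assay, the same methyl in place of hydrogen on a saturated chain carbon, ten or more bonds along the chain from an aromatic nitrogen, that earlier gave a 2.7-fold higher number from compound 2 to compound 3 (0.43 log units; beyond the scatter) now gives a 1.1-fold higher number from compound 3 to compound 4 (0.03 log units; within the scatter), so the rise seen at the first such step did not repeat at the second. Taken together, the change between the chains of the two outer compounds is a 2.9-fold higher number from compound 2 to compound 4 (0.46 log units; beyond the scatter), which leaves compound 2 with the lowest number of the series, while compounds 3 and 4 cannot be told apart. Compound 1 stands at a limit and not at a number, so an at least 3.9-fold lower number from compound 1 to compound 4 (0.59 log units; beyond the scatter) is only a bound: the limit of > 50000 nM in this assay, at which 1 of the 4 values shown sits.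

On these data alone, whether a longer chain than that of compound 4 would keep the number level remains open. So does what a carboxylic acid or an amine in place of the hydroxyl would do on these chains.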